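The source may hold more compounds than are shown below. What is called first, only, known or untested is meant among the compounds shown, and "the series" means these compounds.

Compound 1 `COc1cc(O)c(C(=O)/C=C/c2ccc(F)cc2)c(OC)c1` was examined in a functional assay on HaCaT cells (Homo sapiens) for cytotoxicity, with a stated time of 48 h; on this read-out lower numbers stand for stronger inhibition and higher numbers for weaker inhibition. In this assay compound 1 gives only a limit, > 20000 nM, not a measured number. Going by the values given here, compound 2 `COc1cccc(/C=C/C(=O)c2c(OC)cc(OC)cc2OC)c1` is the one member of the set that returns an actual figure: in this assay compound 2 gives 5300 nM. That places compound 2 as the sole number shown, the other value being a limit (the limit of > 20000 nM in this assay, at which 1 of the 2 values shown sits). Among the compounds with values here, no step between measured compounds can be read from these two, as they differ in more than one place; what they show is simply a number standing beside a limit.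

Compound 3 `COc1cc(OC)c(C(=O)/C=C/c2ccc(Cl)cc2)c(OC)c1` has not yet been measured. It departs from compound 2 by 4-chlorophenyl in place of 3-methoxyphenyl on a double-bonded chain carbon bound to a double-bonded chain carbon. Nothing among the two measured compounds isolates the effect of this exchange, so no shift beyond the usual scatter is expected in either direction in this assay. The step from compound 2 to compound 3 is therefore expected to be modest: a 1.1-fold higher number from compound 2 to compound 3 (0.05 log units; within the scatter). Compound 3 is expected to give 6000 nM, within a range from 2500 nM to 15000 nM.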

Compound 3, half-maximal inhibitory concentration: 7600 nM
Compound 3: middle estimate off by 1.3-fold (0.10 log units), on the low side; the range from low to high includes it.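

Going by these compounds alone, replacing 3-methoxyphenyl with 4-chlorophenyl on a double-bonded chain carbon bound to a double-bonded chain carbon gives the first step that can be read in this assay: a 1.4-fold higher number from compound 2 to compound 3 (0.16 log units; within the scatter). This position therefore accepts this exchange of one substituted phenyl group for the other without a shift beyond the scatter, even though a methoxy group leaves and a chlorine enters, and compound 2 and compound 3 cannot be told apart on this read-out. Compound 1 remains a limit rather than a number, so no step involving it can be read: the limit of > 20000 nM in this assay, at which 1 of the 3 values shown sits.

Because only this one exchange is shown, the compounds leave open whether the outcome depends on the identity of the substituent, on where it sits on the phenyl ring, or on neither. They also leave open whether a phenyl group carrying an amine or a carboxylic acid, or a longer chain in its place, would move the number in this assay beyond the scatter.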